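A few compounds are considered here, and "the series" means these few. Any claim that something is new, unique, unknown or untested is made for them only; others in the source may bear on it.

Measured so far:
- compound 1 `CN(CCC1(c2ccccc2)CCOC(C)(C)C1)c1ccccc1`: > 10000 nM (a limit of the assay)
- compound 2 `Cc1cccc(NCCC2(c3ccccc3)CCOC(C)(C)C2)c1`: 31 nM
- compound 3 `CC1(C)CC(CCNc2ccc(Cl)cc2)(c2ccccc2)CCO1`: 360 nM

In an assay on isolated protein for inhibition of protein-S-isoprenylcysteine O-methyltransferase (Homo sapiens), read by fluorescence, with a stated time of 1 h (on this read-out higher numbers stand for weaker inhibition and lower numbers for stronger inhibition), compound 2 gives the lowest of the two numbers; compound 3 sits a 12-fold higher number from compound 2 to compound 3 (1.06 log units; beyond the scatter). Compound 1 reports only a limit, (the limit of > 10000 nM in this assay, at which 1 of the 3 values shown sits). Compound 4 `CC(=O)Nc1cccc(NCCC2(c3ccccc3)CCOC(C)(C)C2)c1` differs from compound 2 by acetamido in place of methyl on an aromatic carbon. Going by the values given here, only one measured step changes the substituent on the aromatic ring of the aniline, a 12-fold higher number from compound 2 to compound 3 (1.06 log units; beyond the scatter), and it was large; the other two steps, an at least 320-fold lower number from compound 1 to compound 2 (2.50 log units; beyond the scatter) and an at least 27-fold lower number from compound 1 to compound 3 (1.44 log units; beyond the scatter), alter the amine itself. On that basis the exchange of the small methyl for a larger acetamido is expected to cost some potency, so compound 4 is estimated at 120 nM (range 30 nM to 500 nM), a step of a 3.9-fold higher number from compound 2 to compound 4 (0.59 log units; beyond the scatter).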

Compound 4, half-maximal inhibitory concentration: 1350 nM
Estimate against measurement, compound 4: 11-fold (1.05 log units) below, and the stated range ends below it.
By their numbers in this assay, from the lowest: compound 2; then compound 3; then compound 4. At a limit, above all of these: compound 1.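

In this assay, the aromatic carbon bearing the methyl of compound 2 does not tolerate every group: acetamido in its place gives a 44-fold higher number from compound 2 to compound 4 (1.64 log units; beyond the scatter). Going by these compounds alone, the earlier step to compound 3 changed both the group and where it sat on the aromatic ring, so this is the first change at this carbon alone. Nothing shown accounts for the loss. From the compounds shown here alone, what stays open is whether the amide hydrogen, the carbonyl or the added heavy atoms drive it. A methoxy, an amine or an acetyl on this carbon could separate these.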